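The source may hold more compounds than are shown below. What is called first, only, known or untested is meant among the compounds shown, and "the series" means these compounds.

Of the compounds shown here, two sharing one core have been measured so far in a functional assay on HEL cells (Homo sapiens) for cytotoxicity, read by microscopy; a lower number here means a stronger inhibitor, a higher number a weaker inhibitor. Compound 1 (`O=C1O/C(=C\Cn2cc(C(F)(F)F)c(=O)[nH]c2=O)C(OCc2ccccc2)=C1OCc1ccccc1`) gives 2000 nM, the lower of the two numbers, which makes it the stronger inhibitor of the pair. Its nearest neighbour, compound 2 (`O=C1O/C(=C\Cn2cc(Cl)c(=O)[nH]c2=O)C(OCc2ccccc2)=C1OCc1ccccc1`), gives 5000 nM. Still unmeasured is compound 3 (`O=C1O/C(=C\Cn2cc(F)c(=O)[nH]c2=O)C(OCc2ccccc2)=C1OCc1ccccc1`), which differs from compound 1 in one place: fluoro in place of trifluoromethyl on an aromatic carbon.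

Within the data shown here, only one measured step bears on this change. With chloro in place of trifluoromethyl on an aromatic carbon, the number moved by a 2.5-fold higher number from compound 1 to compound 2 (0.40 log units; beyond the scatter), a modest step. That single step from compound 1 suggests that losing trifluoromethyl may cost a little in this assay, but fluoro itself has not been measured on this core, so the size of the change remains uncertain. A modest move towards a higher number is therefore expected, similar to the chloro step, though a result within the scatter of compound 1 would not be surprising. The estimated step is a 2.0-fold higher number from compound 1 to compound 3 (0.30 log units; within the scatter). For compound 3 the expected value is 4000 nM, with an estimated range from 1500 nM to 10000 nM.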

Compound 3, half-maximal inhibitory concentration: 20000 nM
Compound 3: the middle estimate sits 5.0-fold (0.70 log units) below what was measured; the whole stated range lies below it.
By their numbers in this assay, from the lowest: compound 1; then compound 2; then compound 3.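

In this assay, fluoro in place of trifluoromethyl on this aromatic carbon gives a 10-fold higher number from compound 1 to compound 3 (1.00 log units; beyond the scatter) and is the larger of the two steps away from trifluoromethyl, so the position is more sensitive to the choice of group than the chloro step alone suggested. Fluoro in place of chloro gives a 4.0-fold higher number from compound 2 to compound 3 (0.60 log units; beyond the scatter) and shows that exchanging one halogen for another also matters here, which places the three groups in a single order on the shared core: trifluoromethyl gives the lowest number, then chloro, then fluoro. Nothing available explains why the numbers fall in this order.

The three compounds leave open where a plain hydrogen, a methyl group, a bromo group or a nitrile would fall in this order, and so whether any group on this carbon could give a lower number than trifluoromethyl. They also leave open whether the same order would hold on a different core, as all three compounds share one core and differ only in this single group.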